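The compounds below may be only part of what the source reports. "The series", "measured", "known", "first", "only" and "open" are said of these compounds alone.

Measured compounds:
- compound 1 `O=C(Nc1cc(-c2ccccc2)nn1-c1ccccc1)c1ccc(C(F)(F)F)cc1` — 990 nM
- compound 2 `O=C(Nc1cc(-c2ccccc2)nn1-c1ccccc1)c1ccc([N+](=O)[O-])cc1` — 250 nM
- compound 3 `O=C(Nc1cc(-c2ccccc2)nn1-c1ccccc1)c1ccc(Cl)c(Cl)c1` — 160 nM

All three share the core of compound 1 and differ only in the aryl group on the carbonyl carbon. All three were measured in an assay on HEK293 cells for displacement of a labelled ligand from metabotropic glutamate receptor 5 (Rattus norvegicus); a lower number here means a stronger inhibitor, a higher number a weaker inhibitor. Compound 3 stands lowest of the three, but its nearest neighbour is compound 2, and the step of a 1.6-fold lower number from compound 2 to compound 3 (0.19 log units; within the scatter) is within the scatter, so no order between compound 2 and compound 3 can be read. Against compound 1 the separation is clear: a 6.2-fold lower number from compound 1 to compound 3 (0.79 log units; beyond the scatter) and a 4.0-fold lower number from compound 1 to compound 2 (0.60 log units; beyond the scatter) both lie beyond the scatter.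

Compound 4 `O=C(Nc1cc(-c2ccccc2)nn1-c1ccccc1)C1CCCC1` is not yet measured. The change is cyclopentyl in place of 3,4-dichlorophenyl on a carbonyl carbon. For the measured compounds named here, none of the measured steps bears directly on it: each of them keeps a six-membered aromatic ring and changes only what sits on it, whereas here the aromatic ring itself is replaced by a non-aromatic one and three heavy atoms are lost. The expectation for compound 4 is therefore a step toward a higher number, a 9.4-fold higher number from compound 3 to compound 4 (0.97 log units; beyond the scatter), held with wide uncertainty. For compound 4 the estimated value is 1500 nM, with a range from 300 nM to 8000 nM.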

Compound 4, inhibition constant: 11600 nM
Compound 4: middle estimate off by 7.7-fold (0.89 log units), on the low side; measured number outside the range, above it.
By their numbers in this assay, from the lowest: compounds 3 and 2 (each within the scatter of the next); then compound 1; then compound 4.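

For the compounds shown here, at the carbonyl carbon, the move from a substituted phenyl group to cyclopentyl counts for far more in this assay than any exchange among the substituted phenyl groups: a 73-fold higher number from compound 3 to compound 4 (1.86 log units; beyond the scatter) and a 46-fold higher number from compound 2 to compound 4 (1.67 log units; beyond the scatter) and a 12-fold higher number from compound 1 to compound 4 (1.07 log units; beyond the scatter) are all large, while the earlier steps were modest or within the scatter. The step stays beyond the scatter from all three aromatic compounds, including compound 1, so the higher number of compound 4 does not depend on which of these phenyl groups is the reference. The change from compound 3 removes the aromatic ring, alters the ring size and removes both chlorines in a single step, and no measurement here explains the rise or separates these parts.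

The compounds shown leave open whether a cyclohexyl group or an unsubstituted phenyl group on the carbonyl carbon would stand nearer compound 3 or nearer compound 4. Also open, going by these compounds, is how this position would respond to an open carbon chain such as pentyl, or to a ring carrying an amine such as piperidinyl.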